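A few compounds are considered here, and "the series" means these few. Any claim that something is new, unique, unknown or untested is made for them only; others in the source may bear on it.

Working notes on the series

Three compounds of the series have numbers in an assay on NIH3T3 cells with Urotensin-2 receptor (Homo sapiens) as the target; a lower number here means a smaller maximal response, a higher number a larger maximal response. Compound 1 `Cc1ccsc1C(=O)OC(CCN(C)C)c1ccc(Cl)cc1` gives 119%. Compound 2 `Cc1cccc(C(=O)NC(CCN(C)C)c2ccc(Cl)cc2)c1C` gives 159%, and compound 3 `COc1cccc(C(=O)NC(CCN(C)C)c2ccc(Cl)cc2)c1C` gives 179%. Compound 2 stands second highest of the three: compound 3 lies nearest, its number higher and beyond the scatter, while compound 1 lies furthest, its number lower and beyond the scatter. Among the measured compounds shown here, the one single-point step among the measured compounds is a number 20 percentage points higher from compound 2 to compound 3 (beyond the scatter), a modest rise.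

Compound 4 `CN(C)CCC(NC(=O)c1ccccc1)c1ccc(Cl)cc1` is not yet measured in this assay. It differs from compound 2 in one place: phenyl in place of 2,3-dimethylphenyl on a carbonyl carbon. The step from compound 2 to compound 3 is the only measured one that touches this same aromatic ring on the carbonyl carbon; it shows that a change of the substitution there moves the number beyond the scatter. For the measured compounds named here, no measured pair removes substituents from that ring altogether, so the direction for compound 4 is not fixed by the data. Going by the values given here, a modest step downward is expected, since the only measured change at this ring went upward when a substituent was exchanged rather than removed, though a number within the scatter of compound 2 is also plausible. For compound 4 the expected value is 140%, with a range from 110% to 175%, which means an expected step of a number 19 percentage points lower from compound 2 to compound 4 (beyond the scatter).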

Compound 4, largest response reached (reported as efficacy), in percent of the reference or control that the assay uses: 158%
Estimate against measurement, compound 4: 18 percentage points below; measured number inside the range.
By their numbers in this assay, from the lowest: compound 1; then compounds 4 and 2 (each within the scatter of the next); then compound 3.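

In this assay, phenyl in place of 2,3-dimethylphenyl on a carbonyl carbon gives a number 1 percentage points lower from compound 2 to compound 4 (within the scatter), so the two groups cannot be told apart at this position. Among the compounds shown here, until now the only reading at this ring was a number 20 percentage points higher from compound 2 to compound 3 (beyond the scatter), an exchange of methyl for methoxy that showed the number responds to what the ring carries; the new pair adds that the ring needs neither methyl group of compound 2 to hold a number of this size, so a change here does not always move it beyond the scatter. No measured property of these compounds bears on this result.

From the compounds shown here alone, whether a nitrile or a carboxylic acid on the phenyl ring would move the number remains open, as does whether a cyclohexyl group on the carbonyl carbon would hold it. The ester of compound 1 differs from the amides in more than one place, so the share of the ester oxygen against the amide nitrogen in its number cannot be read from the compounds shown.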